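This account rests on a few compounds, and the source may have more. Where it says the series, first, only, none or still open, it means among the compounds named here.

Of the compounds shown here, three have been measured in an assay on HEK293 cells for agonist activity at transient receptor potential cation channel subfamily M member 8 (Homo sapiens), read by fluorescence and calcium flux, with a stated time of 15 min; a lower number here means that less compound is needed, a higher number that more compound is needed for the effect. Compound 1 `Cc1ccc(OCC(=O)N(Cc2cccs2)CC(C)C)cc1` gives 900 nM. Compound 3 `CCN(Cc1cccs1)C(=O)C(C)Oc1ccc(C)cc1` gives 889 nM, and compound 2 `CCCc1ccc(OCC(=O)N(CC)Cc2cccs2)cc1` gives 1810 nM. Among these three numbers compound 1 stands second highest; its nearest neighbour is compound 3, and the gap between them lies within the scatter of repeated measurements, while the furthest, compound 2, also lies within that scatter. The three values therefore tell no order among them.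

The next compound, compound 4 `Cc1ccc(OCC(=O)N(Cc2cccs2)c2ccncc2)cc1`, shares its core with compound 1 and differs in one place: pyridin-4-yl in place of isobutyl on an amide-type nitrogen. Within the data shown here, no measured pair in this set shows a change of this kind, so the data give no step to lean on. The three values that exist all sit close together, so compound 4 is expected to land in the same region, with a modest drift toward a higher number, a 1.7-fold higher number from compound 1 to compound 4 (0.22 log units; within the scatter). The estimate for compound 4 in this assay is 1500 nM, within a range from 400 nM to 6000 nM.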

Compound 4, half-maximal effective concentration: 52 nM
Estimate against measurement, compound 4: 29-fold (1.46 log units) above; the whole stated range lies above it.
By their numbers in this assay, from the lowest: compound 4; then compounds 3, 1 and 2 (each within the scatter of the next, the first and the last beyond it).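

In this assay, among these compounds, pyridin-4-yl in place of isobutyl on the amide-type nitrogen gives a 17-fold lower number from compound 1 to compound 4 (1.24 log units; beyond the scatter) and is the first step here that lies beyond the scatter. It shows that this position is sensitive to what it carries, which the earlier numbers, all within the scatter of one another, gave no sign of. The change swaps an open chain for a six-membered aromatic ring with a hydrogen-bond acceptor, but nothing measured here explains the size of the step.

Phenyl in the same place would show whether the ring alone carries the step, and pyridin-3-yl whether the place of the ring nitrogen counts. From the compounds shown here alone, whether pyridin-4-yl would act the same way on compound 2 or compound 3, which differ elsewhere, also stays open.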